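Ester in place of amide on the side chain

The source may report more compounds than this note shows. Statements on the series, on what has been measured and on what is new or still open speak of the compounds shown alone.

The shared core of compound 1 `Cc1cn([C@@H]2O[C@H](CO[Si](C)(C)C(C)(C)C)[C@@]3(OS(=O)(=O)C=C3NCC(N)=O)[C@H]2O[Si](C)(C)C(C)(C)C)c(=O)n(C)c1=O` carries a carbamoylmethyl group on the amine nitrogen. In a functional assay on HEL cells (Homo sapiens) (a higher number here means that more compound is tolerated, a lower number that less compound is tolerated), compound 1 gives 13500 nM, the lowest of the three numbers measured here. Compound 2 `CCOC(=O)NC(=O)NC1=CS(=O)(=O)O[C@@]12[C@@H](CO[Si](C)(C)C(C)(C)C)O[C@@H](n1cc(C)c(=O)n(C)c1=O)[C@@H]2O[Si](C)(C)C(C)(C)C` gives 14000 nM, and the step of a 1.0-fold higher number from compound 1 to compound 2 (0.02 log units; within the scatter) lies within the scatter. Compound 3 `Cc1cn([C@@H]2O[C@H](CO[Si](C)(C)C(C)(C)C)[C@@]3(OS(=O)(=O)C=C3NCCC(=O)O)[C@H]2O[Si](C)(C)C(C)(C)C)c(=O)n(C)c1=O` gives 34000 nM, the furthest number, and the step of a 2.5-fold higher number from compound 1 to compound 3 (0.40 log units; beyond the scatter) is modest but beyond the scatter.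

Compound 4 `Cc1cn([C@@H]2O[C@H](CO[Si](C)(C)C(C)(C)C)[C@@]3(OS(=O)(=O)C=C3NCCC(=O)OCc3ccccc3)[C@H]2O[Si](C)(C)C(C)(C)C)c(=O)n(C)c1=O` differs from compound 1 in one place: (benzyloxycarbonyl)methyl in place of carbamoyl on a saturated chain carbon bound to an amine nitrogen. The step of a 2.5-fold higher number from compound 1 to compound 3 (0.40 log units; beyond the scatter) bears most directly on this change, since it also replaced the carbamoyl group on the same saturated chain carbon and moved the number higher. The step of a 2.4-fold higher number from compound 2 to compound 3 (0.39 log units; beyond the scatter) moved in the same direction. Within the data shown here, with no measured example of an ester at this position, the expectation is a modest rise of about the same size, with wide uncertainty. For compound 4 the estimated value in this assay is 25000 nM, with a likely range from 10000 nM to 60000 nM, which corresponds to an expected step of a 1.9-fold higher number from compound 1 to compound 4 (0.27 log units; within the scatter).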

Compound 4, half-maximal cytotoxic concentration: 200000 nM
Compound 4: the middle estimate sits 8.0-fold (0.90 log units) below what was measured; the measured number lies above the stated range.
By their numbers in this assay, from the lowest: compounds 1 and 2 (each within the scatter of the next); then compound 3; then compound 4.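

Turning the carboxylic acid of compound 3 into its benzyl ester gives a 5.9-fold higher number from compound 3 to compound 4 (0.77 log units; beyond the scatter) in this assay and so shows that this side chain still responds once the acid hydrogen is replaced by benzyl. Against the two other side chains the change is larger than any seen earlier, with a 15-fold higher number from compound 1 to compound 4 (1.17 log units; beyond the scatter) for the 2-(benzyloxycarbonyl)ethyl group in place of carbamoylmethyl and a 14-fold higher number from compound 2 to compound 4 (1.15 log units; beyond the scatter) for the same group in place of (ethoxycarbonyl)carbamoyl, both large where the earlier steps were at most modest. No measurement bears on why the number rises this far.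

The compounds shown leave open whether the rise goes with the benzene ring or with the ester itself, which a methyl ester and a benzyl amide on the same chain would separate. Also open, from the compounds shown here alone, is how a longer chain between the amine nitrogen and the ester would read in this assay on this core.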